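The source may report more compounds than this note shows. Statements on the series, on what has been measured and on what is new or still open speak of the compounds shown alone.

Measured so far:
compound 1 `CN(C)CCCOc1ccc(CN2CC[C@H](NC(=O)c3cc(Cl)cc(Cl)c3)C2)cc1`: 2000 nM
compound 2 `CC(C)C[C@H](NC(=O)c1ccc2ccccc2n1)C(=O)N[C@H]1CCN(Cc2ccc(OCCCN(C)C)cc2)C1`: 631 nM

In an assay on HEK293 cells for binding affinity to Urotensin-2 receptor (Homo sapiens), read by radioligand binding (a lower number here means a stronger inhibitor, a higher number a weaker inhibitor), compound 2 gives 631 nM, the lower of the two numbers, while compound 1 gives 2000 nM, a gap that lies beyond the usual scatter of repeated measurements. The next compound, compound 3 `CC(C)C[C@H](NC(=O)c1ccccc1)C(=O)N[C@H]1CCN(Cc2ccc(OCCCN(C)C)cc2)C1`, differs from compound 2 in a single place: phenyl in place of quinolin-2-yl on a carbonyl carbon. Going by the values given here, no measured pair with this same change exists, so the size of the step must be guessed from the change itself. With the bicyclic acyl group replaced by a plain one, a weaker binder than compound 2 is expected, and the estimated step from compound 2 to compound 3 in this assay is a 4.0-fold higher number from compound 2 to compound 3 (0.60 log units; beyond the scatter), a loss beyond the scatter. Compound 3 is therefore estimated at 2500 nM, within a range from 800 nM to 8000 nM.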

Compound 3, inhibition constant: 501 nM
Estimate against measurement, compound 3: 5.0-fold (0.70 log units) above; measured number below the stated range.
By their numbers in this assay, from the lowest: compounds 3 and 2 (each within the scatter of the next); then compound 1.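

In this assay, putting phenyl in place of quinolin-2-yl on a carbonyl carbon gives a 1.3-fold lower number from compound 2 to compound 3 (0.10 log units; within the scatter), so this change leaves binding indistinguishable. At this position, then, the aromatic ring of carbon only that remains in benzoyl suffices to hold the number reached with (quinolin-2-yl)carbonyl, and the ring with its hetero atom adds nothing that can be read in this pair. No supporting evidence explains why the two groups read alike.

Still open, going by these compounds, is whether the position accepts other groups, such as pyridin-2-yl, which would separate the ring nitrogen from the second ring, or acetyl, which would remove the aromatic ring altogether. Also open, on these data alone, is what the isobutyl-bearing amide segment contributes alone, as compound 1 differs from both other compounds in more than one place.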